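Removing One Bromine From a Brominated Cytotoxic Scaffold

The compounds below may be only part of what the source reports. "The series", "measured", "known", "first", "only" and "open" are said of these compounds alone.

Compound 1 `COC(=O)C1=C(c2cc(Br)c(O)c(Br)c2)C(=O)[C@](c2ccc(O)c(Br)c2)(c2cc(Br)c(O)c(Br)c2)C1=O` was tested in a functional assay on A549 cells (Homo sapiens) for cytotoxicity, read by sulforhodamine B assay, with a stated time of 72 h; on this read-out lower numbers stand for stronger inhibition and higher numbers for weaker inhibition. In this assay compound 1 gives > 10000 nM, which is a limit of the assay rather than a measured number. A second compound, compound 2 `COC(=O)C1=C(c2cc(Br)c(O)c(Br)c2)[C@](OC)(c2ccc(O)c(Br)c2)O[C@@]1(C(=O)OC)c1cc(Br)c(O)c(Br)c1`, carries the same bromo and hydroxy groups on its rings but a different core. In this assay compound 2 gives > 10000 nM, again a limit and not a number. For the measured compounds named here, compound 1 therefore stands nowhere on a numerical scale: every value known so far sits at the limit of > 10000 nM in this assay, at which 2 of the 2 values shown sit, and no step between measured compounds can be drawn from these data.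

Compound 3 `COC(=O)C1=C(c2ccc(O)c(Br)c2)C(=O)[C@](c2ccc(O)c(Br)c2)(c2cc(Br)c(O)c(Br)c2)C1=O` is the untested compound. It differs from compound 1 in one place: hydrogen in place of bromo on an aromatic carbon. Going by the values given here, nothing measured so far has moved the read-out off its limit, and the single bromine lost here is a small part of a large molecule. The expected step that the limit leaves unreadable from compound 1 to compound 3 is none beyond the scatter, with the result likely to remain a limit. For compound 3 the estimate in this assay is 15000 nM, with a range from 5000 nM to 50000 nM.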

Compound 3, half-maximal inhibitory concentration: > 10000 nM
Compound 3: no number, only a limit; the forecaster's own chance of this, stated with the estimate: 80%; the middle value does not contradict the limit.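

In this assay compound 3 gives > 10000 nM, which is a limit of the assay and not a number. For the compounds shown here, compound 1 and compound 3 both rest on a limit, so no step between them can be read: the limit of > 10000 nM in this assay, at which 3 of the 3 values shown sit. The compounds shown leave open whether hydrogen in place of bromo changes the read-out at all.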